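Saturating and methoxylating the side chain of compound 3

This account rests on a few compounds, and the source may have more. Where it says the series, first, only, none or still open, it means among the compounds named here.

Three members of this tetrahydropyran series have been tested for cytotoxicity in a functional assay on HeLa cells (Homo sapiens) for cytotoxicity, read by WST assay, with a stated time of 48 h; a lower number here means a stronger inhibitor, a higher number a weaker inhibitor. Compound 1 `COc1ccc(CCC[C@@H]2C[C@@H]([C@@H](O)c3ccc(OC)c(OC)c3)CO[C@H]2c2ccc(OC)c(OC)c2)cc1OC` gives 35700 nM. Compound 2 `COc1ccccc1/C=C/C[C@H]1C[C@@H]([C@@H](O)c2ccccc2)CO[C@@H]1c1ccccc1` gives 14700 nM. Compound 3 `COc1ccc([C@H]2OC[C@H]([C@@H](O)c3ccc(OC)c(OC)c3)C[C@@H]2C/C=C/c2ccccc2)cc1OC` gives 14800 nM, which places it second highest of the three numbers; its value and that of compound 2 lie within the scatter of each other, while compound 1 sits beyond the scatter at a higher number.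

The next compound, compound 4 `COc1ccc(CCC[C@H]2C[C@@H]([C@@H](O)c3ccc(OC)c(OC)c3)CO[C@@H]2c2ccc(OC)c(OC)c2)cc1OC`, departs from compound 3 in a single region: 2-(3,4-dimethoxyphenyl)ethyl in place of 2-phenylethenyl on a saturated chain carbon bound to a saturated ring carbon. Among the compounds with values here, no measured pair isolates this change, so the expectation rests on the one related number available. Compound 1, which also carries a 2-(3,4-dimethoxyphenyl)ethyl chain, gives 35700 nM, a weaker inhibition than compound 3 shows. Compound 4 is therefore expected to move toward a higher number, with the step of a 1.7-fold higher number from compound 3 to compound 4 (0.23 log units; within the scatter) estimated as modest and possibly still within the scatter. In this assay compound 4 is estimated at 25000 nM, with a plausible range from 10000 nM to 60000 nM.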

Compound 4, half-maximal inhibitory concentration: 37700 nM
Estimate against measurement, compound 4: 1.5-fold (0.18 log units) below; low and high end bracket the measured number.
By their numbers in this assay, from the lowest: compounds 2 and 3 (each within the scatter of the next); then compounds 1 and 4 (each within the scatter of the next).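

In this assay, within the data shown here, 2-(3,4-dimethoxyphenyl)ethyl in place of 2-phenylethenyl on a saturated chain carbon bound to a saturated ring carbon gives a 2.5-fold higher number from compound 3 to compound 4 (0.41 log units; beyond the scatter), so this exchange is the first at this position with a measured step, modest in size but beyond the scatter. Inverting the two stereocentres at saturated ring carbons leaves no difference that can be told from the scatter, with a 1.1-fold higher number from compound 1 to compound 4 (0.02 log units; within the scatter). This pair therefore isolates configuration from every other structural feature, and within it the drawn configuration does not separate the two numbers: the fact that compounds 1 and 4 differ only in the configuration as drawn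

The exchange removes the double bond and adds the two methoxy groups together, so the compounds shown leave open which of these two differences carries the step. On these data alone, how a chain ending in an amine or a carboxylic acid, or a longer chain, would read at this position also remains open.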